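Butyl for isopropyl on the ring nitrogen of compound 1

A few compounds are considered here, and "the series" means these few. Any claim that something is new, unique, unknown or untested is made for them only; others in the source may bear on it.

Compound 1 `COc1ccc(NC(=O)C(=O)c2cn(C(C)C)c3ccccc23)cn1` is the reference of the series. In a functional assay on FaDu cells (Homo sapiens) for cytotoxicity, read by MTT assay, with a stated time of 72 h (on this read-out lower numbers stand for higher toxicity in this test and higher numbers for lower toxicity in this test), compound 1 gives 85 nM, the lowest of the two numbers in hand. Compound 2 `COc1ccc(NC(=O)C(=O)c2cn(C(C)C)c3cc(Cl)ccc23)cn1` gives 1770 nM, a step of a 21-fold higher number from compound 1 to compound 2 (1.32 log units; beyond the scatter) for chloro in place of hydrogen on an aromatic carbon. Compound 3 `COc1nc(NC(=O)C(=O)c2cn(C(C)C)c3ccccc23)ns1` reaches only a limit, > 10000 nM. The step of an at least 110-fold higher number from compound 1 to compound 3 (2.07 log units; beyond the scatter) runs up to that limit (the limit of > 10000 nM in this assay, at which 1 of the 3 values shown sits). Compound 4 `CCCCn1cc(C(=O)C(=O)Nc2ccc(OC)nc2)c2ccccc21` differs from compound 1 by butyl in place of isopropyl on an aromatic nitrogen. Neither measured step touches the group on the aromatic nitrogen, so no measured change bears directly on this one; an exchange of one short chain for another is expected to give no step beyond the scatter in this assay. For compound 4 the expected value in this assay is 100 nM, with a range of 30 nM to 400 nM. The step of a 1.2-fold higher number from compound 1 to compound 4 (0.07 log units; within the scatter) is thus the expectation.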

Compound 4, concentration lethal to 50% of the cells: 18 nM
Beside the measured number, compound 4's estimate is 5.6-fold (0.74 log units) above it; the whole stated range lies above it.
By their numbers in this assay, from the lowest: compound 4; then compound 1; then compound 2. At a limit, above all of these: compound 3.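

For the compounds shown here, the group on the aromatic nitrogen is the first place where a change lowers the number in this assay: butyl in place of isopropyl gives a 4.7-fold lower number from compound 1 to compound 4 (0.67 log units; beyond the scatter). The two earlier steps, made at other places, both raised the number, so this position responds to a small change of chain, and in the opposite direction. Nothing at hand gives a cause for this step. Going by these compounds, whether a longer chain such as hexyl, or a butyl chain ending in an amine, lowers the number further stays open.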